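The compounds below may be only part of what the source reports. "The series", "measured", "known", "first", "only" and "open" are said of these compounds alone.

In a functional assay on K562 cells (Homo sapiens) for inhibition, read by sulforhodamine B assay, with a stated time of 48 h (a lower number here means a stronger inhibitor of growth, a higher number a weaker inhibitor of growth), compound 1 `CCOC(=O)c1nn(-c2ccc(Cl)cc2)c(-c2ccc(OC)cc2)c1CNC(C)(C)C` yields no single number: its entries read 6100 nM; > 523000 nM (2 entries). One entry of compound 1 is a limit of the assay. For the measured compounds named here, compound 2 `CC(C)(C)NCc1c(C(=O)O)nn(-c2ccc(Cl)cc2)c1-c1ccc(Br)cc1` gives 297000 nM, the only single number available so far. Compound 3 `COc1ccc(-c2c(CNC(C)(C)C)c(C(=O)O)nn2-c2ccc(Cl)cc2)cc1` departs from compound 2 at one place, (methoxy in place of bromo on an aromatic carbon), with methoxy in place of bromo on an aromatic carbon. Going by the values given here, no measured step covers this change, so no shift beyond the scatter is expected in this assay. The expected step is a 1.0-fold higher number from compound 2 to compound 3 (0.00 log units; within the scatter). Compound 3 is estimated at 300000 nM, with an expected range from 100000 nM to 600000 nM.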

Compound 3, concentration for 50% growth inhibition: > 605000 nM
Compound 3: only a limit was reported; the forecaster's own chance of this, stated with the estimate: 35%; middle value at least 2.0-fold (0.30 log units) from the limit.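

In this assay, the change from 4-bromophenyl to 4-methoxyphenyl gives an at least 2.0-fold higher number from compound 2 to compound 3 (0.30 log units; that floor lies within the scatter). The entry for compound 3, > 605000 nM, is a limit and not a number. Going by these compounds, this first step at this position therefore has only a floor, and its true size stays unknown.

On these data alone, it remains open whether fluoro or an amine on this aromatic carbon would give a number clearly apart from that of compound 2. Compound 1, which also carries the 4-methoxyphenyl group, offers no firm single value for comparison: the several entries of compound 1 in this assay, 6100 nM; > 523000 nM (2 entries)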